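The compounds below may be only part of what the source reports. "The series", "measured", "known", "first", "only" and "open" are said of these compounds alone.

Measured so far in a functional assay on K562 cells (Homo sapiens) for cytotoxicity, read by MTT assay, with a stated time of 72 h; on this read-out higher numbers stand for weaker inhibition and lower numbers for stronger inhibition:
- compound 1 (`CC(C)(C)C1=CC(=O)C=C(NCCC(=O)O)C1=O`): 67000 nM
- compound 2 (`CC(C)(C)C1=CC(=O)C=C(NCC(=O)O)C1=O`): 85000 nM

Compound 2 at 85000 nM stands within the scatter of compound 1, so the two numbers give no order. Compound 3 (`CC(C)[C@@H](NC1=CC(=O)C=C(C(C)(C)C)C1=O)C(=O)O`) differs from compound 2 by isopropyl in place of hydrogen on a saturated chain carbon bound to an amine nitrogen and a carbonyl carbon. Within the data shown here, only one measured step is available, a 1.3-fold higher number from compound 1 to compound 2 (0.10 log units; within the scatter), and it alters the chain rather than adding a group at that carbon, so it is a weak guide. Among the measured compounds shown here, no measured step covers this change. With so little to go on, no shift beyond the scatter is expected in this assay, and the expected step is a 1.4-fold lower number from compound 2 to compound 3 (0.15 log units; within the scatter) as an estimate. For compound 3 the estimated value is 60000 nM, with an expected range of 25000 nM to 140000 nM as the outcome.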

Compound 3, half-maximal inhibitory concentration: 57800 nM
Compound 3: the middle estimate sits 1.0-fold (0.02 log units) above what was measured, within the range that was stated.
By their numbers in this assay, from the lowest: compounds 3, 1 and 2 (each within the scatter of the next).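

In this assay, isopropyl in place of hydrogen on a saturated chain carbon bound to an amine nitrogen and a carbonyl carbon gives a 1.5-fold lower number from compound 2 to compound 3 (0.17 log units; within the scatter). Unlike the earlier step, which altered the chain, this one adds 3 heavy atoms at that carbon, and even so the read-out does not separate the two compounds, so this change gives no sign that this carbon governs the cytotoxicity read-out. No supporting evidence bears on this result.

On these data alone, it remains open whether a benzyl or phenyl group at this carbon would move the number beyond the scatter, and whether the opposite configuration at the isopropyl-bearing carbon would do so. Also open, as far as these compounds go, is whether an amide in place of the carboxylic acid would shift the read-out.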